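From 3-fluorophenyl to pyridin-2-yl on the cyano compound

A few compounds are considered here, and "the series" means these few. Any claim that something is new, unique, unknown or untested is made for them only; others in the source may bear on it.

Measured so far in an ADME assay on a cell-free system (plasma, Rattus norvegicus) for protein binding; on this read-out lower numbers stand for a smaller free fraction and higher numbers for a larger free fraction

Compound 1 `NS(=O)(=O)c1ccc(OCCCN2CCC(C(O)(c3cccc(F)c3)c3nccs3)CC2)cc1` gives 0.322
Compound 2 `N#Cc1ccc(OCCCN2CCC(C(O)(c3cccc(F)c3)c3nccs3)CC2)cc1` gives 0.108

Going by the values given here, compound 2 holds the lower of the two numbers, with a 3.0-fold lower number from compound 1 to compound 2 (0.47 log units; beyond the scatter) as the only measured step. Compound 3 `N#Cc1ccc(OCCCN2CCC(C(O)(c3ccccn3)c3nccs3)CC2)cc1` has pyridin-2-yl in place of 3-fluorophenyl on a saturated chain carbon bound to an aromatic carbon, an oxygen on a saturated carbon and a saturated ring carbon. The measured step put cyano in place of sulfamoyl elsewhere and bears only indirectly, as a guide to size. Among the compounds with values here, no step at the new place has been measured, and the direction is a tentative expectation. A modest rise is expected, namely a 1.9-fold higher number from compound 2 to compound 3 (0.27 log units; within the scatter). In this assay the estimate for compound 3 is 0.2 (expected range 0.11 to 0.36).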

Compound 3, unbound fraction: 0.074
Estimate against measurement, compound 3: 2.7-fold (0.43 log units) above, outside the stated range (below it).
By their numbers in this assay, from the lowest: compounds 3 and 2 (each within the scatter of the next); then compound 1.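

In this assay the exchange of 3-fluorophenyl for pyridin-2-yl gives a 1.5-fold lower number from compound 2 to compound 3 (0.16 log units; within the scatter) at this position, on a saturated chain carbon bound to an aromatic carbon, an oxygen on a saturated carbon and a saturated ring carbon. This first reading at the position shows that bringing in a ring nitrogen and a hydrogen-bond acceptor, with one heavy atom fewer, leaves the two cyano compounds within the scatter of each other, whereas the earlier change at the sulfamoyl place lay beyond it. Nothing at hand accounts for this result.

On these data alone, whether the same exchange would behave alike on the sulfamoyl compound remains open. So does the effect on the unbound fraction of an aminomethyl group or a carboxylic acid on a phenyl ring at this position.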